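A few compounds are considered here, and "the series" means these few. Any claim that something is new, unique, unknown or untested is made for them only; others in the source may bear on it.

In a functional assay on A549 cells (Homo sapiens) for inhibition, read by XTT assay, with a stated time of 48 h (on this read-out higher numbers stand for weaker inhibition and lower numbers for stronger inhibition), compound 1 `CC(=O)OC/C(=C\c1ccc(Cl)cc1Cl)C(=O)c1ccccc1` gives 97000 nM and compound 2 `COc1ccc(C(=O)/C(=C/c2ccccc2F)COC(C)=O)cc1` gives 22500 nM. Compound 3 `COc1ccc(C(=O)/C(=C/c2ccccc2F)CCOC(C)=O)cc1` reaches only the limit of this assay, > 100000 nM. The step of an at least 4.4-fold higher number from compound 2 to compound 3 (0.64 log units; beyond the scatter) is thus known only as a bound, and compound 3 stands without a number of its own among the three, as the limit of > 100000 nM in this assay, at which 1 of the 3 values shown sits, records. Compound 4 `COc1ccc(C(=O)/C(=C/c2ccccc2Cl)CCOC(C)=O)cc1` differs from compound 3 by chloro in place of fluoro on an aromatic carbon. Within the data shown here, none of the measured steps carries this exchange, so no step beyond the scatter is expected in this assay in either direction. Compound 4 is expected to give 150000 nM, within a range from 60000 nM to 400000 nM, most probably again as a limit. The expected step is a step that the limit leaves unreadable from compound 3 to compound 4.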

Compound 4, half-maximal inhibitory concentration: > 100000 nM
Compound 4: a limit, no number; the forecaster's own chance of this, stated with the estimate: 70%; the middle value does not contradict the limit.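

No step can be read from compound 3 to compound 4, since both stop at the same limit: the limit of > 100000 nM in this assay, at which 2 of the 4 values shown sit.

The compounds shown leave open how chloro and fluoro compare on that aromatic carbon.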